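Efficacy notes on the pendant aryl of the shared core

The source may report more compounds than this note shows. Statements on the series, on what has been measured and on what is new or still open speak of the compounds shown alone.

Three analogues of the shared core have been read in an assay on isolated protein for agonist activity at Bile acid receptor (Homo sapiens), read by AlphaScreen, with a stated time of 30 min; on this read-out lower numbers stand for smaller maximal responses and higher numbers for larger maximal responses. Compound 1 `Cc1ccccc1-n1nc(C)c2c1NC(=O)[C@H](C)S[C@@H]2c1ccc(-c2ccccc2)cc1` gives 24%, compound 2 `Cc1ccccc1-n1nc(C)c2c1NC(=O)[C@H](C)S[C@@H]2c1ccc(Oc2ccccc2)cc1` gives 118%, and compound 3 `Cc1nn(-c2ccccc2C(C)C)c2c1[C@@H](c1ccc(Oc3ccccc3)cc1)S[C@@H](C)C(=O)N2` gives 174%. Compound 2 thus stands second highest of the three, with compound 3 nearest at a number 56 percentage points higher from compound 2 to compound 3 (beyond the scatter) and compound 1 furthest at a step of a number 94 percentage points higher from compound 1 to compound 2 (beyond the scatter) in the other direction.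

Compound 4 `CCOc1cccc(-c2ccc([C@H]3S[C@@H](C)C(=O)Nc4c3c(C)nn4-c3ccccc3C)cc2)c1` is the next member. Relative to compound 2 the change is 3-ethoxyphenyl in place of phenoxy on an aromatic carbon. Going by the values given here, of the measured steps, only the one from compound 1 to compound 2 touches the same position: there, phenoxy in place of phenyl on the aromatic carbon produced a number 94 percentage points higher from compound 1 to compound 2 (beyond the scatter). The step from compound 2 to compound 3 alters a different aromatic carbon and does not bear on the present change. Among the compounds with values here, compound 4 carries a directly attached aryl again, as compound 1 does, with an ethoxy added; the direction of the step from compound 1 to compound 2 therefore suggests a drop in this assay beyond the scatter, though the added ethoxy has no measured counterpart and the size is uncertain. Compound 4 is expected to give 60%, within 20% to 115%, a step of a number 58 percentage points lower from compound 2 to compound 4 (beyond the scatter).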

Compound 4, largest response reached (reported as efficacy), in percent of the reference or control that the assay uses: 13%
For compound 4 the middle estimate is 47 percentage points above the measured one; measured number outside the range, below it.
By their numbers in this assay, from the lowest: compound 4; then compound 1; then compound 2; then compound 3.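

In this assay, the change to 3-ethoxyphenyl gives a number 105 percentage points lower from compound 2 to compound 4 (beyond the scatter), so the low response of a directly attached aryl in compound 1 also holds for a substituted aryl, with the added ethoxy giving a number 11 percentage points lower from compound 1 to compound 4 (beyond the scatter), and all three compounds with a methyl-bearing aryl on the pyrazole-free reading of the core can be sorted by this group alone: phenoxy in compound 2 stands high, directly attached aryl in compound 1 and compound 4 stands low.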